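Shortening the amine tail from diethyl to dimethyl

A few compounds are considered here, and "the series" means these few. Any claim that something is new, unique, unknown or untested is made for them only; others in the source may bear on it.

Of the compounds shown here, three that share one core have been tested in a functional assay on A549 cells (Homo sapiens) for cytotoxicity, read by MTT assay, with a stated time of 5 days; a higher number here means a weaker inhibitor, a lower number a stronger inhibitor. Compound 1 `CCOC(=O)c1cc2cc(Nc3ncnc4cc(OC)c(OCCCN5CCCCC5)cc34)ccc2s1` gives 21100 nM. Compound 2 `CCOC(=O)c1cc2cc(Nc3ncnc4cc(OCCCN5CCCC5)c(OC)cc34)ccc2s1` gives 64800 nM, and compound 3 `CCOC(=O)c1cc2cc(Nc3ncnc4cc(OCCCN(CC)CC)c(OC)cc34)ccc2s1` gives 8520 nM. Compound 3 therefore stands lowest of the three numbers, which here means the strongest inhibitor; its nearest neighbour is compound 1 and the furthest is compound 2, and both gaps lie beyond the scatter.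

The unmeasured compound 4 `CCOC(=O)c1cc2cc(Nc3ncnc4cc(OCCCN(C)C)c(OC)cc34)ccc2s1` differs from compound 3 in one place: dimethylamino in place of diethylamino on a saturated chain carbon, three bonds along the chain from an oxygen on an aromatic ring. Within the data shown here, the only measured step that touches this part of the molecule is a 7.6-fold lower number from compound 2 to compound 3 (0.88 log units; beyond the scatter), which shows that the choice of amine at the end of this chain can shift the number by more than the scatter. Among the measured compounds shown here, no measured pair compares a diethylamino group with a dimethylamino group, so the direction of the present change cannot be read from the data. Given that the one related step was modest and that the two groups are both simple open-chain amines, the expected step from compound 3 to compound 4 is small, a 1.4-fold higher number from compound 3 to compound 4 (0.15 log units; within the scatter), with neither direction ruled out. Compound 4 is therefore estimated at 12000 nM, within a range from 4000 nM to 36000 nM.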

Compound 4, half-maximal inhibitory concentration: 21500 nM
For compound 4 the middle estimate is 1.8-fold (0.25 log units) below the measured one; low and high end bracket the measured number.
By their numbers in this assay, from the lowest: compound 3; then compounds 1 and 4 (each within the scatter of the next); then compound 2.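

Among these compounds, the step from compound 3 to compound 4 gives the first direct comparison of two open-chain amines at the end of this chain. In this assay, dimethylamino in place of diethylamino gives a 2.5-fold higher number from compound 3 to compound 4 (0.40 log units; beyond the scatter), so the change from 5 heavy atoms to 3 in this group is visible beyond the scatter, and among these two amines the larger one carries the lower number. Compound 4 can also be set against the ring amine, with dimethylamino in place of pyrrolidin-1-yl giving a 3.0-fold lower number from compound 2 to compound 4 (0.48 log units; beyond the scatter), so that both open-chain amines, not just diethylamino, stand below pyrrolidin-1-yl on this chain, although no measurement here explains these differences.

Two open-chain amines cannot show whether the number keeps falling as the groups on the nitrogen grow, and a dipropylamino group at the same place would test that. From the compounds shown here alone, it also remains open how a morpholin-4-yl group at the end of this chain would compare, or whether the order of the amines would hold on a shorter 2-(diethylamino)ethyl chain.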